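The compounds below may be only part of what the source reports. "The series", "measured", "known", "first", "only" and "open" are said of these compounds alone.

Measured so far:
- compound 1 `CCC/C=C/C(=O)N(Cc1ccc(OC)c(O)c1)c1cc(OC)c(OC)c(OC)c1`: 57 nM
- compound 2 `COC(=O)c1cc(CNc2cc(OC)c(OC)c(OC)c2)ccc1OC`: 41100 nM

Within the data shown here, in a functional assay on KYSE-450 cells (Homo sapiens) for inhibition, read by MTT assay, with a stated time of 48 h (a lower number here means a stronger inhibitor, a higher number a weaker inhibitor), compound 1 gives 57 nM, the lowest of the two numbers known here. Compound 2, built on the same core but carrying a methyl ester and lacking the amide carbonyl, gives 41100 nM in this assay, a far higher number and a gap well beyond the usual scatter. Compound 3 `COc1ccc(CN(C(C)=O)c2cc(OC)c(OC)c(OC)c2)cc1O` keeps the whole frame of compound 1 and changes only the group on the amide carbonyl: methyl in place of pent-1-en-1-yl on a carbonyl carbon. Among the measured compounds shown here, no measured pair shows this exact change, so its effect is unknown. Given how strongly compound 1 stands at 57 nM, a moderate step toward a higher number is expected, an 11-fold higher number from compound 1 to compound 3 (1.02 log units; beyond the scatter), rather than a collapse of the kind seen with compound 2. Compound 3 is therefore estimated at 600 nM, within a range of 100 nM to 4000 nM.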

Compound 3, half-maximal inhibitory concentration: 160 nM
Estimate against measurement, compound 3: 3.8-fold (0.57 log units) above; low and high end bracket the measured number.
By their numbers in this assay, from the lowest: compound 1; then compound 3; then compound 2.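

In this assay, putting methyl in place of pent-1-en-1-yl on a carbonyl carbon gives a 2.8-fold higher number from compound 1 to compound 3 (0.45 log units; beyond the scatter) and so costs only modestly. The longer chain with its double bond therefore adds to the strength of compound 1, yet it is not required for a low number: compound 3 still gives 160 nM with only methyl at this place. Nothing shown here gives a reason for this shift.

As far as these compounds go, the step removes chain length and the double bond together, so the share of each in the difference stays open. A saturated pentyl chain on the same carbonyl carbon would separate the two, and a phenyl ring there would show whether this place also accepts a ring.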